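The source may report more compounds than this note shows. Statements on the series, on what has been measured and on what is new or still open speak of the compounds shown alone.

Of the compounds shown here, three built on a shared core have been measured in an assay on HEK293 cells for negative allosteric modulation of metabotropic glutamate receptor 5 (Homo sapiens), read by FLIPR; a lower number here means a stronger inhibitor, a higher number a weaker inhibitor. Compound 1 `CC1CCC(C(=O)N2CC(c3nc(-c4cccc(Cl)c4)no3)C2)CC1` gives > 10000 nM, which is a limit of the assay and not a number. Compound 2 `O=C(N1CCC(F)CC1)N1CC(c2nc(-c3cccc(Cl)c3)no2)C1` gives > 10000 nM, again a limit rather than a number. Within the data shown here, compound 3 `O=C(c1ccc(F)cc1)N1CC(c2nc(-c3cccc(Cl)c3)no2)C1` gives 4000 nM, the only number among the three; the other two values sit at the limit of > 10000 nM in this assay, at which 2 of the 3 values shown sit. The step of an at least 2.5-fold lower number from compound 1 to compound 3 (0.39 log units; beyond the scatter) and the step of an at least 2.5-fold lower number from compound 2 to compound 3 (0.39 log units; beyond the scatter) are thus only lower bounds on how far compound 3 lies from the two limit compounds, and the step that the two limits leave unreadable from compound 1 to compound 2 cannot be read at all. Compound 4 `O=C(c1cccc(F)c1)N1CC(c2nc(-c3cccc(Cl)c3)no2)C1` differs from compound 3 by 3-fluorophenyl in place of 4-fluorophenyl on a carbonyl carbon. Among the measured compounds shown here, none of the measured steps moves a fluorine within a phenyl ring; each exchanges the whole group on the carbonyl carbon, so no measured step bears directly on this change. The expected step is no change at the digits printed from compound 3 to compound 4 (within the scatter), within the scatter. Compound 4 is therefore estimated at 4000 nM, with a range from 1500 nM to 12000 nM.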

Compound 4, half-maximal inhibitory concentration: 780 nM
Compound 4: middle estimate off by 5.1-fold (0.71 log units), on the high side, outside the stated range (below it).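

Placing 3-fluorophenyl instead of 4-fluorophenyl on the carbonyl carbon gives a 5.1-fold lower number from compound 3 to compound 4 (0.71 log units; beyond the scatter) in this assay, so the place of the fluorine on this aromatic ring matters, even though the counts of atoms stay the same. With 3-fluorophenyl in place of the non-aromatic groups, the result is an at least 12-fold lower number from compound 2 to compound 4 (1.10 log units; beyond the scatter) and an at least 12-fold lower number from compound 1 to compound 4 (1.10 log units; beyond the scatter). Both of these steps are lower bounds only, since compounds 1 and 2 each give a limit and not a number: the limit of > 10000 nM in this assay, at which 2 of the 4 values shown sit.

On these data alone, it remains open whether a phenyl without fluorine, or a phenyl bearing chlorine or a nitrile instead of fluorine, would do better or worse on this carbonyl carbon. Among these compounds, only one pair speaks to moving the fluorine, so it is also unknown whether the step would carry over with other groups on the shared core.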